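Changing the Amine Substituent of Compound 1

A few compounds are considered here, and "the series" means these few. Any claim that something is new, unique, unknown or untested is made for them only; others in the source may bear on it.

Measured so far:
compound 1 `COc1cc(Oc2cccc(Nc3ccccc3)c2)cc(OC)c1CNCCNC(C)=O` — 18200 nM
compound 2 `COc1cc(Oc2cccc(Nc3ccccc3)c2)cc(OC)c1CNC(C)C` — a limit of the assay, > 20000 nM

Among the compounds with values here, in a functional assay on HCT-116 cells (Homo sapiens) for inhibition, read by MTT assay, with a stated time of 72 h (a higher number here means a weaker inhibitor, a lower number a stronger inhibitor), compound 1 gives 18200 nM, the only number in the set. Compound 2 reaches only a limit of the assay, > 20000 nM, as recorded in the limit of > 20000 nM in this assay, at which 1 of the 2 values shown sits. Within the data shown here, the single measured step, an at least 1.0-fold higher number from compound 1 to compound 2 (0.04 log units; that floor lies within the scatter), exchanges the substituent on the amine nitrogen and therefore bears on the change at hand, though as a floor it sets no clear direction.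

Compound 3 `COc1cc(Oc2cccc(Nc3ccccc3)c2)cc(OC)c1CNCc1ccc(O)cc1` differs from compound 1 by 4-hydroxyphenyl in place of acetamidomethyl on a saturated chain carbon bound to an amine nitrogen. Among the measured compounds shown here, since the one comparable step stays within the scatter, compound 3 is expected to remain close to compound 1, with an expected step of a 1.2-fold lower number from compound 1 to compound 3 (0.08 log units; within the scatter) in this assay. The estimate for compound 3 in this assay is 15000 nM, with a range from 5000 nM to 40000 nM.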

Compound 3, half-maximal inhibitory concentration: 3360 nM
The estimate for compound 3 lay 4.5-fold (0.65 log units) above the measured number; the measured number lies below the stated range.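

Unlike the earlier exchange on this nitrogen, 4-hydroxyphenyl in place of acetamidomethyl on a saturated chain carbon bound to an amine nitrogen gives a 5.4-fold lower number from compound 1 to compound 3 (0.73 log units; beyond the scatter), showing that the substituent at this place can move the number in this assay beyond the scatter. The change from isopropyl to 4-hydroxybenzyl on the amine nitrogen points the same way, with an at least 5.9-fold lower number from compound 2 to compound 3 (0.77 log units; beyond the scatter). That step is only a floor, because compound 2 stands at a limit of the assay: the limit of > 20000 nM in this assay, at which 1 of the 3 values shown sits.

The compounds shown leave open whether the lower number belongs to the aromatic ring or to its hydroxyl group, a question that a plain benzyl or a 4-methoxybenzyl group on the same nitrogen would address. Also open, from the compounds shown here alone, is how the length of the chain matters, which a 2-phenylethyl group would test.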